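Cytotoxicity of two imidazopyridine analogues and an untested thioether

The source may hold more compounds than are shown below. What is called first, only, known or untested is meant among the compounds shown, and "the series" means these compounds.

Measured compounds:
compound 1 `C=Cc1ccc(-c2cc(C)c3ncc(CSCc4ccccc4)n3c2)cc1` — 59 ug/mL
compound 2 `Cc1cc(N2CCCC2)cn2c(CSCCc3ccccc3)cnc12` — 12 ug/mL

The two measured compounds were tested in an ADME assay on HEL cells (Homo sapiens) for cytotoxicity, with a stated time of 3 days; on this read-out higher numbers stand for lower toxicity in this test and lower numbers for higher toxicity in this test. Compound 1 gives 59 ug/mL in this assay, while compound 2 gives 12 ug/mL, the lower of the two numbers; the gap between them lies beyond the usual scatter, so compound 2 is the more cytotoxic of the pair on this read-out.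

Compound 3 `Cc1cc(Sc2ccc(Cl)cc2)cn2c(CSCCc3ccccc3)cnc12` has not yet been measured. Compared with compound 2, it carries (4-chlorophenyl)sulfanyl in place of pyrrolidin-1-yl on an aromatic carbon. Among the measured compounds shown here, no measured pair in this set shows the effect of that exchange, so there is no step to draw on. The account therefore rests on compound 2 alone, whose number in this assay is 12 ug/mL.

A step of modest size is expected, without a firm direction, and the difference may well stay within the scatter: the step of a 1.7-fold higher number from compound 2 to compound 3 (0.22 log units; within the scatter) is the estimate. Compound 3 is estimated at 20 ug/mL in this assay, with a range from 6 ug/mL to 60 ug/mL.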

Compound 3, half-maximal cytotoxic concentration: 14 ug/mL
Compound 3: the middle estimate sits 1.4-fold (0.15 log units) above what was measured, within the range that was stated.
By their numbers in this assay, from the lowest: compounds 2 and 3 (each within the scatter of the next); then compound 1.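

In this assay, putting (4-chlorophenyl)sulfanyl in place of pyrrolidin-1-yl on this aromatic carbon, two atoms from the ring nitrogen, gives a 1.2-fold higher number from compound 2 to compound 3 (0.07 log units; within the scatter), so the exchange does not separate the two compounds on this read-out. Among the compounds shown here, this is the first single-place exchange in the set, and it shows that a group of 5 heavy atoms with a five-membered non-aromatic ring and one of 8 heavy atoms with a six-membered aromatic ring of carbon only give numbers within the scatter of each other at this position. No supporting data are available to explain this result.

The compounds shown leave open which part of the entering group, the sulfur link or the chlorine, contributes to the read-out, and whether a plain phenylsulfanyl group would read the same way. For the compounds shown here, they also leave open whether a group of another kind on this carbon, such as a primary amine or a carboxylic acid, would stay within the scatter of compound 2, and whether this exchange would read alike with a side chain other than the one compound 2 and compound 3 share.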